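Carbamate variation on aryl selenocyanate and diselenide growth inhibitors

A few compounds are considered here, and "the series" means these few. Any claim that something is new, unique, unknown or untested is made for them only; others in the source may bear on it.

Compound 1 `CC(C)COC(=O)Nc1ccc([Se][Se]c2ccc(NC(=O)OCC(C)C)cc2)cc1` — 19900 nM
Compound 2 `CC(C)COC(=O)Nc1ccc([Se]C#N)cc1` — 8100 nM
Compound 3 `Cc1ccc(OC(=O)Nc2ccc([Se][Se]c3ccc(NC(=O)Oc4ccc(C)cc4)cc3)cc2)cc1` — 7900 nM

In a functional assay on HT-29 cells (Homo sapiens) for cytotoxicity, read by MTT assay, with a stated time of 72 h (a lower number here means a stronger inhibitor of growth, a higher number a weaker inhibitor of growth), compound 2 gives 8100 nM, the second highest of the three numbers; compound 3 lies within the scatter of it, while compound 1 stands beyond the scatter with a higher number. Compound 4 `N#C[Se]c1ccc(NC(=O)Oc2ccccc2)cc1` differs from compound 2 by phenyl in place of isobutyl on an oxygen next to a carbonyl group. Going by the values given here, no step between measured compounds covers this single change; compound 1 and compound 3 differ at two carbamates rather than one, and their two values show the lower number for compound 3. Compound 4 is therefore expected to give a somewhat lower number than compound 2, a step of a 1.6-fold lower number from compound 2 to compound 4 (0.21 log units; within the scatter) that only just passes the scatter. The estimate for compound 4 is 5000 nM, with a range from 2000 nM to 14000 nM.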

Compound 4, concentration for 50% growth inhibition: 11700 nM
Beside the measured number, compound 4's estimate is 2.3-fold (0.37 log units) below it, and the stated range covers the measured number.
By their numbers in this assay, from the lowest: compounds 3, 2, 4 and 1 (each within the scatter of the next, the first and the last beyond it).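

At this position, on an oxygen next to a carbonyl group, phenyl in place of isobutyl gives a 1.4-fold higher number from compound 2 to compound 4 (0.16 log units; within the scatter) in this assay. Going by these compounds alone, this is the first step that isolates the carbamate group, and it shows that the six-membered aromatic ring and the isobutyl chain cannot be told apart here. Nothing available explains this result.

As far as these compounds go, whether a longer chain or a benzyl group on this oxygen would move the number beyond the scatter remains open. Also open, from the compounds shown here alone, is whether this single change reads the same on a diselenide.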